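One Fluorine-Rich Group Exchanged on an Aromatic Carbon

The source may report more compounds than this note shows. Statements on the series, on what has been measured and on what is new or still open speak of the compounds shown alone.

- compound 1 `CC(O)(CSc1ccccc1OC(F)(F)F)C(=O)Nc1ccc(S(F)(F)(F)(F)F)cc1` with 10600 nM
- compound 2 `CC(O)(CSc1ccc(S(F)(F)(F)(F)F)cc1)C(=O)Nc1cccc(S(F)(F)(F)(F)F)c1` with 12700 nM
- compound 3 `CC(O)(CSc1ccc(OC(F)(F)F)cc1)C(=O)Nc1cccc(S(F)(F)(F)(F)F)c1` not yet measured

Both numbers come from a functional assay on LNCaP cells (Homo sapiens) for antiproliferative activity, read by propidium iodide staining, with a stated time of 96 h (on this read-out higher numbers stand for weaker inhibition and lower numbers for stronger inhibition), and are the only data available. Compound 2 at 12700 nM and compound 1 at 10600 nM lie within the usual scatter of each other, so on these numbers the two stand level.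

Compound 3 differs from compound 2 in one place (a group of 5 heavy atoms (1 carbon, 1 oxygen, 3 fluorine; no ring) in place of a group of 6 heavy atoms (5 fluorine, 1 sulfur; no ring), on an aromatic carbon), on an aromatic carbon of a six-membered aromatic ring of carbon only, para to a large group. A trifluoromethoxy group enters there.

Going by the values given here, no measured pair shows this exchange on its own, so the evidence is thin. Among the compounds with values here, compound 1, the one measured compound carrying trifluoromethoxy, gives 10600 nM and so lies within the scatter of compound 2, although the two differ in more than this group. No step beyond the scatter is therefore expected in this assay in either direction. The estimated step is a 1.1-fold lower number from compound 2 to compound 3 (0.02 log units; within the scatter) and stays inside that scatter. The estimate for compound 3 is 12000 nM with 6000 nM and 25000 nM as the expected ends of its range.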

Compound 3, half-maximal inhibitory concentration: 10300 nM
Estimate against measurement, compound 3: 1.2-fold (0.07 log units) above, and the stated range covers the measured number.
By their numbers in this assay, from the lowest: compounds 3, 1 and 2 (each within the scatter of the next).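

Going by these compounds alone, for the first time, two compounds differ in one place only, so this exchange can be read on its own. In this assay, trifluoromethoxy takes the place of the group of 5 fluorine and 1 sulfur, on an aromatic carbon para to a large group, and this gives a 1.2-fold lower number from compound 2 to compound 3 (0.09 log units; within the scatter), so the two groups stand level at this position on this core. That holds even though the group that enters carries a hydrogen-bond acceptor and the group that leaves carries none, but no measurement shown here explains why the two groups read alike.

As far as these compounds go, whether this position would stay level with a group of a different kind, such as an amine, a carboxylic acid or a longer alkyl chain, or with a plain hydrogen, remains open. From the compounds shown here alone, it is also open whether the same exchange would give a similar step at another place on the shared core or in another cell line.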